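The source may hold more compounds than are shown below. What is called first, only, known or untested is meant among the compounds shown, and "the series" means these compounds.

Measured compounds:
- compound 1 `CCCNCc1cc(-c2c(C(=O)NCC)noc2-c2cc(C(C)C)c(O)cc2O)on1`: "not determined" (no result reported) in a functional assay on A2780 cells (Homo sapiens) for inhibition; on this read-out lower numbers stand for stronger inhibition and higher numbers for weaker inhibition
- compound 2 `CCNC(=O)c1noc(-c2cc(C(C)C)c(O)cc2O)c1-c1cc(CN(C)C)no1`: 31 nM
- compound 3 `CCNC(=O)c1noc(-c2cc(C(C)C)c(O)cc2O)c1-c1cc(C(=O)O)no1`: 20000 nM

Among the measured compounds shown here, compound 3 stands at the highest of the two numbers recorded in this assay; the single measured step, a 650-fold higher number from compound 2 to compound 3 (2.81 log units; beyond the scatter), came with carboxy in place of (dimethylamino)methyl on an aromatic carbon. Compound 1 gives no number and cannot be placed.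

Compound 4 `CCNC(=O)c1noc(-c2cc(C(C)C)c(O)cc2O)c1-c1cn[nH]c1` is the next entry. Its change from compound 3 is 1H-pyrazol-4-yl in place of 3-carboxy-1,2-oxazol-5-yl on an aromatic carbon. The carboxy group thus leaves together with its ring, and a smaller five-membered aromatic ring with two nitrogen atoms enters at the same place. For the measured compounds named here, the one step that bears on this is a 650-fold higher number from compound 2 to compound 3 (2.81 log units; beyond the scatter), which shows how far the carboxy-bearing ring sits from the (dimethylamino)methyl-bearing ring. Compound 4 carries neither of these groups, so the expectation is a large move back toward the number of compound 2, though not necessarily all the way; an estimated 130-fold lower number from compound 3 to compound 4 (2.12 log units; beyond the scatter) is expected. For compound 4 in this assay the estimate is 150 nM, with a range of 25 nM to 1000 nM.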

Compound 4, half-maximal inhibitory concentration: 38 nM
The estimate for compound 4 lay 3.9-fold (0.60 log units) above the measured number, and the stated range covers the measured number.
By their numbers in this assay, from the lowest: compounds 2 and 4 (each within the scatter of the next); then compound 3.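

In this assay the step of a 530-fold lower number from compound 3 to compound 4 (2.72 log units; beyond the scatter) shows that this position on the shared core can give a low number without the (dimethylamino)methyl group of compound 2. With a 1.2-fold higher number from compound 2 to compound 4 (0.09 log units; within the scatter) the 1H-pyrazol-4-yl and 3-((dimethylamino)methyl)-1,2-oxazol-5-yl groups cannot be told apart, so among the compounds shown an amine on this substituent is not needed for a low number, and compound 3 with its 3-carboxy-1,2-oxazol-5-yl group is the only outlier. No supporting data explain this result. The step from compound 3 to compound 4 changes the ring and the carboxy group together, so their shares stay unseparated. An unsubstituted 1,2-oxazol-5-yl group or a methyl ester on that ring would separate them, and the propylaminomethyl group of compound 1 remains unplaced.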